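Adding a Second Chloro to Compound 3

The compounds below may be only part of what the source reports. "The series", "measured", "known", "first", "only" and "open" are said of these compounds alone.

Of the compounds shown here, three sharing one core have been measured in a functional assay on CHO cells with adenosine receptor A1 (Homo sapiens) as the target, read by cAMP accumulation and immunoassay, with a stated time of 6 min, tested at 0.01 uM; on this read-out lower numbers stand for a stronger effect and higher numbers for a weaker effect at the one concentration tested. Compound 1 `Nc1scc(CN2CCN(c3ccc(Cl)cc3F)CC2)c1C(=O)c1ccc(Cl)cc1` gives -9.2%. Compound 2 `Nc1scc(CN2CCN(c3ccc(F)c(F)c3)CC2)c1C(=O)c1ccc(Cl)cc1` gives -3.2% in this assay. Compound 3 `Nc1scc(CN2CCN(c3cccc(Cl)c3)CC2)c1C(=O)c1ccc(Cl)cc1` gives -3.1% in this assay. Compound 3 carries the highest number of the three, yet the gaps to the others, a number 0.1 percentage points higher from compound 2 to compound 3 (within the scatter) and a number 6.1 percentage points higher from compound 1 to compound 3 (within the scatter), both lie within the scatter, so no real difference between the three is shown.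

Compound 4 `Nc1scc(CN2CCN(c3cc(Cl)ccc3Cl)CC2)c1C(=O)c1ccc(Cl)cc1` has not yet been measured. It differs from compound 3 by chloro in place of hydrogen on an aromatic carbon. Among the measured compounds shown here, two measured steps bear on this change, since each alters the group on the same amine nitrogen in a ring: a number 6.1 percentage points higher from compound 1 to compound 3 (within the scatter) and a number 0.1 percentage points higher from compound 2 to compound 3 (within the scatter). Both lay within the scatter, as did a number 6 percentage points higher from compound 1 to compound 2 (within the scatter). Every change so far to the group on that nitrogen has left the read-out in this assay essentially unmoved, and nothing in the data suggests a chloro at this place would act differently. Accordingly, compound 4 is expected to show no step beyond the scatter, a number 0.1 percentage points higher from compound 3 to compound 4 (within the scatter), in this assay. The estimate for compound 4 is -3%, with a range from -13% to 7%.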

Compound 4, a percentage reported as activity, at one concentration (the size of the read-out at that concentration, not a potency): 13%
Estimate against measurement, compound 4: 16 percentage points below; measured number outside the range, above it.
By their numbers in this assay, from the lowest: compounds 1, 2 and 3 (each within the scatter of the next); then compound 4.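

In this assay, among the compounds shown here, this chloro, ortho to a large group and para to a chloro group, is the first change to the group on the amine nitrogen that moves the read-out beyond the scatter, with a number 16.1 percentage points higher from compound 3 to compound 4 (beyond the scatter) towards a weaker effect, though the step is modest. The 2,5-dichlorophenyl group also stands apart from the other two groups on that nitrogen, with a number 16.2 percentage points higher from compound 2 to compound 4 (beyond the scatter) and a number 22.2 percentage points higher from compound 1 to compound 4 (beyond the scatter), both likewise modest, so this position is not as indifferent to substitution as the 3-chlorophenyl, 3,4-difluorophenyl and 4-chloro-2-fluorophenyl compounds alone had suggested. Nothing among the data shown explains why this one added chlorine shifts the number when the earlier exchanges did not.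

The compounds shown leave open whether the shift belongs to chloro itself or would also follow from another group at this place, such as a methyl, a methoxy or an amine. Going by these compounds, each number also comes from a single concentration, so how this step would look as a difference in potency remains open as well.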